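Switching sulfanyl to fluorophenoxy on the quinoxaline-diamine core

A few compounds are considered here, and "the series" means these few. Any claim that something is new, unique, unknown or untested is made for them only; others in the source may bear on it.

Of the compounds shown here, three sharing one core have been tested in a functional assay on HOP-62 cells (Homo sapiens) for inhibition, read by sulforhodamine B assay, with a stated time of 48 h; on this read-out lower numbers stand for stronger inhibition of growth and higher numbers for weaker inhibition of growth. Compound 1 `Nc1cc(N)c2nc(-c3ccccc3)c(Oc3ccc(Cl)c(Cl)c3)nc2c1` gives 38000 nM. Compound 3 `Nc1cc(N)c2nc(-c3ccccc3)c(Sc3ccc(Cl)c(Cl)c3)nc2c1` gives 77600 nM, the higher of the two numbers measured, and the step of a 2.0-fold higher number from compound 1 to compound 3 (0.31 log units; beyond the scatter) places it beyond the scatter. Compound 2 `COc1ccc(Sc2nc3cc(N)cc(N)c3nc2-c2ccccc2)cc1` gives only a limit of the assay, < 100000 nM. That limit, (the limit of < 100000 nM in this assay, at which 1 of the 3 values shown sits), leaves the steps a step that the limit leaves unreadable from compound 1 to compound 2 and a step that the limit leaves unreadable from compound 2 to compound 3 unreadable.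

Compound 4 `Nc1cc(N)c2nc(-c3ccccc3)c(Oc3ccc(F)cc3)nc2c1` has not yet been measured. It differs from compound 3 by the change (4-fluorophenoxy in place of (3,4-dichlorophenyl)sulfanyl on an aromatic carbon). Two parts of this change can be weighed separately. The exchange of sulfur for oxygen as the linking atom has a measured counterpart: the step from compound 1 to compound 3, a 2.0-fold higher number from compound 1 to compound 3 (0.31 log units; beyond the scatter), went in the opposite direction and was modest. Reversing it should therefore yield a modestly lower number in this assay. Within the data shown here, the exchange of two chlorines for one fluorine on the pendant ring has no readable counterpart, since the only comparison of ring substituents involves the limit of compound 2.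

On that basis compound 4 is expected to show 30000 nM, estimated between 10000 nM and 90000 nM, which would mean a step of a 2.6-fold lower number from compound 3 to compound 4 (0.41 log units; beyond the scatter) relative to compound 3.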

Compound 4, concentration for total growth inhibition: 49000 nM
Compound 4: middle estimate off by 1.6-fold (0.21 log units), on the low side; the measured number falls inside the stated range.
By their numbers in this assay, from the lowest: compounds 1, 4 and 3 (each within the scatter of the next, the first and the last beyond it).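

In this assay, placing 4-fluorophenoxy where (3,4-dichlorophenyl)sulfanyl stood, on the aromatic carbon next to the ring nitrogen, gives a 1.6-fold lower number from compound 3 to compound 4 (0.20 log units; within the scatter), so this larger change in the substituent leaves no difference that can be told from the scatter. Among these compounds, the result also supplies the first readable comparison of substituents on the pendant ring: with oxygen as the link, 4-fluorophenyl in place of 3,4-dichlorophenyl gives a 1.3-fold higher number from compound 1 to compound 4 (0.11 log units; within the scatter), so the two rings cannot be told apart here, and only the step between the two 3,4-dichlorophenyl compounds lies beyond the scatter. Compound 2 gives a limit and not a number, so its step to compound 4, like its other steps, cannot be read: the limit of < 100000 nM in this assay, at which 1 of the 4 values shown sits.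

The compounds shown leave open how the pendant ring behaves on sulfur, since the only sulfur-linked comparison of ring substituents rests on that limit. They also leave open whether an amine, a carboxylic acid or a longer alkyl chain at this aromatic carbon, in place of the aryl groups linked through oxygen or sulfur, would move the number beyond the scatter.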